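From propanoyl to ethylsulfonyl on a shared core

The source may hold more compounds than are shown below. What is called first, only, known or untested is meant among the compounds shown, and "the series" means these compounds.

Measured so far in an ADME assay on the whole organism (plasma) for pharmacokinetics, with Rattus norvegicus as the target; a higher number here means faster removal of the compound, a lower number slower removal 
- compound 1 `CCS(=O)(=O)n1cc2c(n1)CN([C@H]1CO[C@H](c3cc(F)ccc3F)[C@@H](N)C1)C2` gives 1.6 mL/min/kg
- compound 2 `N[C@H]1C[C@@H](N2Cc3cnn(S(=O)(=O)C4CCCC4)c3C2)CO[C@@H]1c1cc(F)ccc1F` gives 96 mL/min/kg
- compound 3 `CCC(=O)Nc1n[nH]c2c1CN([C@H]1CO[C@H](c3cc(F)ccc3F)[C@@H](N)C1)C2` gives 60 mL/min/kg

In this assay compound 3 (60 mL/min/kg) lies within the usual scatter of compound 2 (96 mL/min/kg). Compound 1 gives 1.6 mL/min/kg. Compound 3 stands far higher than compound 1, a gap beyond the scatter. Among the compounds with values here, the next compound is compound 4 `CCS(=O)(=O)Nc1n[nH]c2c1CN([C@H]1CO[C@H](c3cc(F)ccc3F)[C@@H](N)C1)C2`, which has ethylsulfonyl in place of propanoyl on a nitrogen on an aromatic ring as its only change from compound 3.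

Within the data shown here, no measured pair shows this change on its own, so the evidence is indirect. Compound 1 carries ethylsulfonyl and gives a low number (1.6 mL/min/kg), but it differs from compound 3 in more than one place. Compound 2 also carries a sulfonyl group, yet it gives a high number (96 mL/min/kg), so it goes against any simple rule about sulfonyl groups. A drop beyond the scatter is therefore expected, though with little certainty, and the estimated size is a 3.0-fold lower number from compound 3 to compound 4 (0.48 log units; beyond the scatter) in this assay. The expected value for compound 4 is 20 mL/min/kg (from 5 mL/min/kg to 70 mL/min/kg).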

Compound 4, clearance: 12 mL/min/kg
Compound 4: the middle estimate sits 1.7-fold (0.22 log units) above what was measured, within the range that was stated.
By their numbers in this assay, from the lowest: compound 1; then compound 4; then compounds 3 and 2 (each within the scatter of the next).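

In this assay, within the data shown here, putting ethylsulfonyl in place of propanoyl on a nitrogen on an aromatic ring gives a 5.0-fold lower number from compound 3 to compound 4 (0.70 log units; beyond the scatter), the first reading of this change with the rest of the molecule held fixed. This shows that the group on this nitrogen can, on its own, shift the rate of removal by more than the usual scatter. No accompanying measurement offers an explanation for the shift.

The compounds shown leave open how methylsulfonyl or a longer chain such as butylsulfonyl would behave on this same nitrogen, and what a free amine there would do. Among these compounds, with only one such pair, it also remains unknown whether this change would shift the number in the same direction on a different core.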